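From diethoxymethyl to a ring at one aromatic carbon

The compounds below may be only part of what the source reports. "The series", "measured", "known", "first", "only" and "open" are said of these compounds alone.

Values in a functional assay on HFF cells (Homo sapiens) for cytotoxicity, read by neutral red uptake; on this read-out lower numbers stand for higher toxicity in this test and higher numbers for lower toxicity in this test:
- compound 1 `CC(=O)OC[C@H]1OC(n2cc(C=O)c(=O)[nH]c2=O)C[C@@H]1OC(C)=O` gives > 300000 nM
- compound 2 `CCOC(OCC)c1cn(C2C[C@H](OC(C)=O)[C@@H](COC(C)=O)O2)c(=O)[nH]c1=O` gives > 300000 nM
- compound 3 `CCOC(OCC)c1cn(C2C[C@H](O)[C@@H](CO)O2)c(=O)[nH]c1=O` gives > 300000 nM

Compound 2 reads > 300000 nM and this is a limit, not a number. Among the measured compounds shown here, the series so far offers only the limit of > 300000 nM in this assay, at which 3 of the 3 values shown sit, and nothing finer. Going on to compound 4 `CC(=O)OC[C@H]1OC(n2cc(C3OCCCO3)c(=O)[nH]c2=O)C[C@@H]1OC(C)=O` replaces the diethoxymethyl group on an aromatic carbon (a group of 6 heavy atoms (4 carbon, 2 oxygen; one six-membered non-aromatic ring with 2 hetero atoms) in place of a group of 7 heavy atoms (5 carbon, 2 oxygen; no ring), on an aromatic carbon) with the rest unchanged. For the measured compounds named here, the one measured step at this carbon is a step that the two limits leave unreadable from compound 1 to compound 2 and it gives no size to carry over. No step beyond the scatter is therefore expected in this assay and the expected step is a number no higher from compound 2 to compound 4 (the limit leaves the size open) in size. For compound 4 the estimate is 300000 nM with an expected range from 150000 nM to 600000 nM and a report as a limit is likely.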

Compound 4, half-maximal cytotoxic concentration: > 300000 nM
Compound 4 ended at the assay's limit (the forecaster's own chance of this, stated with the estimate: 85%); the middle value sits exactly at the limit.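

In this assay compound 4 gives > 300000 nM, which is a limit and not a number. No step can be read among compound 1, compound 2 and compound 4, as all three stand at limits. The compounds shown leave open whether any change at this aromatic carbon would give a number in this assay.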